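The compounds below may be only part of what the source reports. "The series", "measured", "known", "first", "only" and "open" are said of these compounds alone.

Measured compounds:
Compound 1, `Cc1ccc(F)cc1NC(=O)Nc1cc(C(C)(C)C)nn1-c1ccccc1`: 6 degrees C
Compound 2, `CC(C)(C)c1cc(NC(=O)Nc2ccccc2)n(-c2ccccc2)n1`: 7.7 degrees C
Compound 3, `COc1cccc(NC(=O)Nc2cc(C(C)(C)C)nn2-c2ccccc2)c1`: 3.6 degrees C

In an assay on isolated protein for inhibition of STE20-like serine/threonine-protein kinase (Homo sapiens), read by thermal shift assay, tested at 10 uM (a higher number here means that the compound stabilises the target more against heat, a lower number that the compound stabilises the target less), compound 3 stands lowest of the three, with compound 1 nearest and compound 2 furthest from it. The step of a number 2.4 degrees C lower from compound 1 to compound 3 (beyond the scatter) and the step of a number 4.1 degrees C lower from compound 2 to compound 3 (beyond the scatter) both place compound 3 clearly under its neighbours; the step of a number 1.7 degrees C higher from compound 1 to compound 2 (beyond the scatter) shows that the plain phenyl urea sits highest of all.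

Compound 4, `CC(C)(C)c1cc(NC(=O)Nc2cc(F)cc(F)c2)n(-c2ccccc2)n1`, has not been measured in this assay. Its change from compound 3 is 3,5-difluorophenyl in place of 3-methoxyphenyl on an amide-type nitrogen. The step that bears most directly on it is a number 4.1 degrees C lower from compound 2 to compound 3 (beyond the scatter), since the methoxy group leaves again in compound 4; that step was large, and its reversal would by itself point upward. The step of a number 1.7 degrees C higher from compound 1 to compound 2 (beyond the scatter) is also relevant, as compound 1 carries a fluorine on the same ring and sat somewhat below compound 2. Taken together, compound 4 is expected to move upward from compound 3 by a modest to large step, a number 2.9 degrees C higher from compound 3 to compound 4 (beyond the scatter), landing between compound 1 and compound 2 rather than above them. Compound 4 is therefore estimated at 6.5 degrees C, with a range from 4.5 degrees C to 8.5 degrees C.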

Compound 4, shift of the target's melting temperature: 3 degrees C
The estimate for compound 4 lay 3.5 degrees C above the measured number, outside the stated range (below it).
By their numbers in this assay, from the lowest: compounds 4 and 3 (each within the scatter of the next); then compound 1; then compound 2.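

In this assay, the exchange of 3-methoxyphenyl for 3,5-difluorophenyl on the amide-type nitrogen reads as a number 0.60 degrees C lower from compound 3 to compound 4 (within the scatter), so these two rings cannot be told apart here and the low number of compound 3 is not unique to a methoxy-bearing ring. The steps from the other two rings are larger, a number 4.7 degrees C lower from compound 2 to compound 4 (beyond the scatter) and a number 3.0 degrees C lower from compound 1 to compound 4 (beyond the scatter); all three substituted rings among these compounds now stand under the plain phenyl of compound 2, while fluorine on the ring does not settle the outcome, since compound 1 also carries fluorine and stands clearly higher than compound 4. No measurement at hand explains why the methoxy and difluoro rings give such similar numbers.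

The compounds shown leave open whether a single fluorine or a single methyl group on this ring would lower the number by itself, or whether the effect seen in compound 4 needs both of its fluorines. They also leave open how this position would respond to an amine or a carboxylic acid on the ring, or to a longer chain in place of the ring.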